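A few compounds are considered here, and "the series" means these few. Any claim that something is new, unique, unknown or untested is made for them only; others in the source may bear on it.

Measured compounds:
Compound 1, `Cc1cc(=O)oc2cc(OCc3cn(-c4ccc(F)c(Cl)c4)nn3)ccc12`, in an ADME assay on Huh-7 cells (Homo sapiens) for cytotoxicity, read by MTT assay, with a stated time of 72 h (a higher number here means that more compound is tolerated, a lower number that less compound is tolerated), gives > 100 ug/mL, which is a limit of the assay rather than a number.
Compound 2, `Cc1cc(=O)oc2cc(OCc3cn(-c4ccc(F)cc4)nn3)ccc12`, in this assay gives > 100 ug/mL, again a limit and not a number.
Compound 3, `Cc1cc(=O)oc2cc(OCc3cn(-c4ccc(Oc5ccccc5)cc4)nn3)ccc12`, in this assay gives > 100 ug/mL, also a limit.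

Compound 2 therefore stands at the same limit as the other two measured compounds: every value shown sits at the limit of > 100 ug/mL in this assay, at which 3 of the 3 values shown sit, and nothing separates the three in this assay. Within the data shown here, the step that the two limits leave unreadable from compound 1 to compound 2 and the step that the two limits leave unreadable from compound 2 to compound 3 both run from one limit to another, so their size cannot be read; they show only that exchanging the group on the aryl ring of the triazole did not bring the half-maximal cytotoxic concentration down into the measurable range.

Compound 4, `COC(=O)Cn1cc(COc2ccc3c(C)cc(=O)oc3c2)nn1`, has not been measured. It differs from compound 2 in this way: (methoxycarbonyl)methyl in place of 4-fluorophenyl on an aromatic nitrogen. Both measured steps change the substituent on the same aromatic nitrogen, so both bear on this change, but neither yields a readable size. No step beyond the scatter is expected in this assay. Compound 4 is estimated to give 150 ug/mL in this assay, with the expected step that the limit leaves unreadable from compound 2 to compound 4, most likely reported once more as a limit rather than a number.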

Compound 4, half-maximal cytotoxic concentration: > 100 ug/mL
Compound 4: no number, only a limit (the forecaster's own chance of this, stated with the estimate: 80%); the middle value lies beyond the limit too.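

Compound 4 also gives only a limit in this assay, so neither its step from compound 2 nor its step from compound 1 can be read. All four compounds stand at the same value: the limit of > 100 ug/mL in this assay, at which 4 of the 4 values shown sit.

The compounds shown leave open where the actual half-maximal cytotoxic concentrations of compound 1, compound 2, compound 3 and compound 4 lie, and whether the group on the aromatic nitrogen alters them at all.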